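The compounds below may be only part of what the source reports. "The series", "measured", "known", "first", "only" and "open" are said of these compounds alone.

In a functional assay on the whole organism (strain Swiss albino) with Mus musculus as the target, in the maximal electroshock model, with a stated time of 4 h (on this read-out higher numbers stand for an effect only at larger amounts of compound and lower numbers for an effect already at smaller amounts), compound 1 `O=C(N/N=C\c1cccc(O)c1)Nc1nnc(COc2ccc3ccccc3c2)o1` gives 300 mg/kg. Compound 2 `O=C(N/N=C(/c1ccccc1)c1ccc(O)cc1)Nc1nnc(COc2ccc3ccccc3c2)o1` in this assay gives 300 mg/kg, so compound 1 stands level with compound 2 at the digits reported, the two values lying within the usual scatter of such measurements. Within the data shown here, the two compounds share a core and differ only in the group on a carbon with a double bond to nitrogen, and no step between them beyond the scatter is on record, so the known numbers give no direction for how an exchange at that place moves the dose.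

Compound 3 `CN(C)c1ccc(/C=N\NC(=O)Nc2nnc(COc3ccc4ccccc4c3)o2)cc1` has yet to be tested in this assay. Relative to compound 1 it carries 4-(dimethylamino)phenyl in place of 3-hydroxyphenyl on a carbon with a double bond to nitrogen. The expectation is that the change from compound 1 to compound 3 brings no step beyond the scatter in this assay, no change at the digits printed from compound 1 to compound 3 (within the scatter) being estimated as essentially none, because compound 1 gives 300 mg/kg and compound 2 gives 300 mg/kg despite their own difference at the same carbon. Compound 3 is therefore estimated at 300 mg/kg, within a range from 100 mg/kg to 600 mg/kg.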

Compound 3, minimum effective dose: 300 mg/kg
For compound 3 middle estimate and measured number coincide at the digits printed; the range from low to high includes it.
By their numbers in this assay, from the lowest: compounds 1, 2 and 3 (each within the scatter of the next).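

In this assay, among these compounds, placing 4-(dimethylamino)phenyl in place of 3-hydroxyphenyl on a carbon with a double bond to nitrogen brings no change at the digits printed from compound 1 to compound 3 (within the scatter), which gives this place its first readable step, since the earlier compounds offered none. The exchange is not a small one by the counts: the leaving group has 7 heavy atoms and 1 hydrogen-bond donor, the entering group 9 heavy atoms and 0 hydrogen-bond donors, and the read-out still stays within the scatter, so at this place, for this pair, neither difference comes with a measurable shift in dose. No further data bear on this result, and nothing here accounts for it.

With every compound shown at the same value, it remains open whether any exchange on this carbon can move the dose at all. A carboxylic acid on the aromatic ring, or a short alkyl chain in place of that ring, would test whether this flat result holds beyond aromatic groups of this kind.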